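The compounds below may be only part of what the source reports. "The series", "measured", "known", "first", "only" and "open" are said of these compounds alone.

Working notes on the series. All three compounds share one core, a methyl on the ring and a second, varied substituent on the same ring. Compound 1, `Cc1ccc(-c2cc(C)oc(=O)c2)cc1`, carries a methyl-bearing phenyl as that substituent. In a functional assay on K562 cells (Homo sapiens) for inhibition (a lower number here means a stronger inhibitor, a higher number a weaker inhibitor), compound 1 returns only the limit of the assay, > 50000 nM, and no number. Compound 2, `CCc1cc(C)oc(=O)c1`, carries an ethyl instead. In this assay compound 2 likewise returns only the assay limit, > 50000 nM, so where it stands is known only as a limit. Going by the values given here, both values shown sit at that limit (the limit of > 50000 nM in this assay, at which 2 of the 2 values shown sit), and no step between measured compounds can be sized.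

Compound 3, `CCCCc1cc(C)oc(=O)c1`, lengthens the chain: ethyl in place of hydrogen on a saturated chain carbon, two bonds along the chain from an aromatic carbon. The only fixed point for the estimate is that compound 2 gives no number but the limit > 50000 nM. On that basis the expected step is a step that the limit leaves unreadable from compound 2 to compound 3, that is none beyond the scatter in either direction. Compound 3 is therefore estimated at 80000 nM, with a range from 20000 nM to 300000 nM, and most probably again reported only as a limit.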

Compound 3, half-maximal inhibitory concentration: > 50000 nM
Compound 3 ended at the assay's limit; the forecaster's own chance of this, stated with the estimate: 85%; the middle value does not contradict the limit.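

Compound 3 returns in this assay only the limit > 50000 nM and no number. No step from compound 2 to compound 3 can be read, and none between any other compounds shown, because every value sits at the same limit: the limit of > 50000 nM in this assay, at which 3 of the 3 values shown sit. The compounds shown leave open whether any substituent on the shared core gives a readable value in this assay at all.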